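The compounds below may be only part of what the source reports. "The series", "measured", "known", "first", "only" and "open" are said of these compounds alone.

Series notes. Compound 1 `Cn1cc(C(=O)Nc2ccc(-c3ccccc3)c(C(F)(F)F)c2)c(=O)c2cnccc21` carries the shared core unsubstituted at the position in question; compound 2 `Cn1cc(C(=O)Nc2ccc(-c3ccccc3)c(C(F)(F)F)c2)c(=O)c2ccc(CO)cc21` and compound 3 `Cn1cc(C(=O)Nc2ccc(-c3ccccc3)c(C(F)(F)F)c2)c(=O)c2ccc(CCO)cc21` carry the hydroxymethyl and the 2-hydroxyethyl groups there. In an in vitro ADME assay on microsomes from liver (Rattus norvegicus) for metabolic stability, with a stated time of 30 min, tested at 1 uM (a higher number here means faster removal of the compound, a lower number slower removal), compound 1 gives < 14 mL.min-1.g-1, which is a limit of the assay. In this assay compound 2 gives < 14 mL.min-1.g-1, again a limit. In this assay compound 3 gives < 14 mL.min-1.g-1, also a limit, so compound 3 sits with the other two at the limit of < 14 mL.min-1.g-1 in this assay, at which 3 of the 3 values shown sit. The step that the two limits leave unreadable from compound 2 to compound 3 therefore cannot be sized. Compound 4 `Cn1cc(C(=O)Nc2ccc(-c3ccccc3)c(C(F)(F)F)c2)c(=O)c2ccc(C(=O)O)cc21` differs from compound 3 by carboxy in place of 2-hydroxyethyl on an aromatic carbon. No readable measured step bears on this change; the expectation is that a step that the limit leaves unreadable from compound 3 to compound 4 stays within the scatter. Compound 4 is accordingly estimated at 7 mL.min-1.g-1, within 3 mL.min-1.g-1 to 14 mL.min-1.g-1.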

Compound 4, intrinsic clearance in microsomes: < 14 mL.min-1.g-1
Compound 4 was reported as a limit; the forecaster's own chance of this, stated with the estimate: 85%; the middle value lies beyond the limit too.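

The steps to compound 4 from compound 2 and from compound 3 cannot be read in this assay: the limit of < 14 mL.min-1.g-1 in this assay, at which 4 of the 4 values shown sit. The compounds shown leave open whether hydroxymethyl, 2-hydroxyethyl and carboxy differ at all in intrinsic clearance.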